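Oxazolidinone amide series: aryl substituent swap

The source may report more compounds than this note shows. Statements on the series, on what has been measured and on what is new or still open speak of the compounds shown alone.

Measured so far:
- compound 1 `CSc1cccc(CCCCCC(=O)N2CCOC2=O)c1`: 12800 nM
- compound 2 `O=C(CCCCCc1ccc(CO)cc1)N1CCOC1=O`: 190 nM

In an assay on HEK293 cells for inhibition of N-acylethanolamine-hydrolyzing acid amidase (Rattus norvegicus), read by LC-MS, with a stated time of 30 min (on this read-out lower numbers stand for stronger inhibition and higher numbers for weaker inhibition), compound 1 gives 12800 nM, the higher of the two numbers recorded and thus the weaker of the two, while compound 2 gives 190 nM in this assay; the gap between them lies well beyond the scatter. The two compounds differ in more than one place, so no single structural step can be read from that pair.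

Compound 3 `Cc1cccc(CCCCCC(=O)N2CCOC2=O)c1` is not yet measured. It differs from compound 1 by a change at one point: methyl in place of methylsulfanyl on an aromatic carbon, counted as methyl in place of methylsulfanyl on an aromatic carbon. Going by the values given here, no measured pair reports this kind of exchange, so there is no direct precedent to draw on. The expectation is a small step, of the order of the scatter or only slightly beyond it, with no firm direction; the estimated step from compound 1 to compound 3 in this assay is a 1.2-fold higher number from compound 1 to compound 3 (0.07 log units; within the scatter). For compound 3 the estimate in this assay is 15000 nM, within a range of 5000 nM to 45000 nM.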

Compound 3, half-maximal inhibitory concentration: 350 nM
Estimate against measurement, compound 3: 43-fold (1.63 log units) above; measured number below the stated range.
By their numbers in this assay, from the lowest: compounds 2 and 3 (each within the scatter of the next); then compound 1.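

In this assay, putting methyl in place of methylsulfanyl on an aromatic carbon, meta to a large group, brings a 37-fold lower number from compound 1 to compound 3 (1.56 log units; beyond the scatter). Going by these compounds alone, this is the first single-point reading, and it shows that this position is far from indifferent to what it carries: a small exchange on an otherwise unchanged core moves the number by much more than the scatter. The change removes the sulfur and the hydrogen-bond acceptor counted for methylsulfanyl and also lowers the heavy-atom count, and no measurement available here separates these features or links the step to any property of either group.

Still open, on these data alone, is whether the sulfur or the size of the group governs the step; methoxy and ethyl at this same place, or an unsubstituted ring, would help to separate the two. Compound 2 differs from compound 3 in more than one place, so the effect of where a group sits on the ring also remains unread.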